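Diaryl urea series: amide substituent on the alkene linker

The source may hold more compounds than are shown below. What is called first, only, known or untested is meant among the compounds shown, and "the series" means these compounds.

Among the measured compounds shown here, compound 3 `O=C(/C=C/c1ccc(NC(=O)Nc2ccc(Cl)c(C(F)(F)F)c2)cc1)NC1CCC1` gives 7510 nM in a functional assay on HepG2 cells (Homo sapiens) for inhibition, read by MTT assay, with a stated time of 120 h (on this read-out higher numbers stand for weaker inhibition and lower numbers for stronger inhibition), the lowest of the three numbers so far. Compound 1 `CNC(=O)C#Cc1ccc(NC(=O)Nc2ccc(Cl)c(C(F)(F)F)c2)cc1` gives 23300 nM and compound 2 `CNC(=O)/C(C)=C/c1ccc(NC(=O)Nc2ccc(Cl)c(C(F)(F)F)c2)cc1` gives 44300 nM. The step of a 3.1-fold lower number from compound 1 to compound 3 (0.49 log units; beyond the scatter) and the step of a 5.9-fold lower number from compound 2 to compound 3 (0.77 log units; beyond the scatter) each changed the linker and the amide substituent together, so neither isolates one part. Compound 4 `CNC(=O)/C=C/c1ccc(NC(=O)Nc2ccc(Cl)c(C(F)(F)F)c2)cc1` differs from compound 3 by methyl in place of cyclobutyl on an amide-type nitrogen. For the measured compounds named here, no measured pair carries this change alone; compound 1 also bears the methylcarbamoyl but with a different linker. The expectation for compound 4 is therefore a modestly higher number than compound 3, expressed as a 2.0-fold higher number from compound 3 to compound 4 (0.30 log units; within the scatter), and short of the number for compound 1. Compound 4 is estimated at 15000 nM, within 6000 nM to 40000 nM.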

Compound 4, half-maximal inhibitory concentration: 20400 nM
Estimate against measurement, compound 4: 1.4-fold (0.13 log units) below; the range from low to high includes it.
By their numbers in this assay, from the lowest: compound 3; then compounds 4, 1 and 2 (each within the scatter of the next, the first and the last beyond it).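

With the ethenyl linker held constant, the amide nitrogen can now be read alone: methyl in place of cyclobutyl gives (a 2.7-fold higher number from compound 3 to compound 4 (0.43 log units; beyond the scatter)). With the methylcarbamoyl held constant, 2-(methylcarbamoyl)ethenyl reads better than 2-(methylcarbamoyl)prop-1-en-1-yl (a 2.2-fold lower number from compound 2 to compound 4 (0.34 log units; beyond the scatter)), while it cannot be separated from 2-(methylcarbamoyl)ethynyl (a 1.1-fold lower number from compound 1 to compound 4 (0.06 log units; within the scatter)). No measured evidence accounts for these steps.

Still open, as far as these compounds go, is whether cyclobutyl keeps its advantage on the ethynyl linker. Also open, from the compounds shown here alone, is how a cyclopentyl, a longer alkyl chain or a chain ending in an amine would read on the same amide nitrogen.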